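The source may report more compounds than this note shows. Statements on the series, on what has been measured and on what is new or still open speak of the compounds shown alone.

Measured so far in an assay on HEK293 cells for inhibition of Indoleamine 2,3-dioxygenase 1 (Homo sapiens), with a stated time of 30 min; a lower number here means that less compound is needed, a higher number that more compound is needed for the effect:
- compound 1 `N#Cc1ccc(Cn2cncc2-c2cc3cc(Br)ccc3[nH]2)cc1`: 6920 nM
- compound 2 `Brc1ccc2[nH]c(-c3cncn3CC3CCCCN3)cc2c1`: 10700 nM

Compound 2 stands at the higher of the two numbers, but its nearest neighbour is compound 1, and the step of a 1.5-fold higher number from compound 1 to compound 2 (0.19 log units; within the scatter) lies within the scatter, so the two cannot be ordered. Compound 3 `Nc1ccccc1Cn1cncc1-c1cc2cc(Br)ccc2[nH]1` has not yet been measured. It differs from compound 2 by 2-aminophenyl in place of piperidin-2-yl on a saturated chain carbon bound to an aromatic nitrogen. Among the compounds with values here, the only measured step that touches this position is the one from compound 1 to compound 2, an exchange of 4-cyanophenyl for piperidin-2-yl, and it gave a 1.5-fold higher number from compound 1 to compound 2 (0.19 log units; within the scatter). Within the data shown here, nothing measured so far shows this position to move the number beyond the scatter; the 2-aminophenyl group of compound 3 returns to an aromatic ring as in compound 1, so the expectation is a step of a 1.8-fold lower number from compound 2 to compound 3 (0.25 log units; within the scatter), not beyond the scatter. Compound 3 is estimated at 6000 nM, with a range from 2000 nM to 20000 nM.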

Compound 3, half-maximal effective concentration: 12000 nM
Compound 3: the middle estimate sits 2.0-fold (0.30 log units) below what was measured, and the stated range covers the measured number.
By their numbers in this assay, from the lowest: compounds 1, 2 and 3 (each within the scatter of the next).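

In this assay, 2-aminophenyl in place of piperidin-2-yl gives a 1.1-fold higher number from compound 2 to compound 3 (0.05 log units; within the scatter) and 2-aminophenyl in place of 4-cyanophenyl gives a 1.7-fold higher number from compound 1 to compound 3 (0.24 log units; within the scatter) on the same saturated chain carbon bound to an aromatic nitrogen. Neither an aromatic ring of carbon only nor a six-membered non-aromatic ring with 1 hetero atom is separated from the other here, and the two aromatic groups, nitrile-bearing and amino-bearing, are not separated either, so all three groups at this place now read as one level. No evidence to hand bears on this result.

Still open, going by these compounds, is whether a group of another kind at this place, such as a carboxylic acid or a plain methyl, would move the number beyond the scatter. Also open, on these data alone, is whether a longer chain between the aromatic nitrogen and the ring would do so.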